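Swapping Chloro for Trifluoromethyl on a Weakly Toxic Urea

The source may report more compounds than this note shows. Statements on the series, on what has been measured and on what is new or still open speak of the compounds shown alone.

Compound 2 `O=C(Nc1cccc(-n2cc(-c3ccncc3)c(-c3ccc(Cl)c(O)c3)n2)c1)Nc1ccc(Cl)c(Cl)c1` was tested in a functional assay on SF-539 cells (Homo sapiens) for inhibition, read by sulforhodamine B assay, with a stated time of 48 h; on this read-out higher numbers stand for lower toxicity in this test and lower numbers for higher toxicity in this test. In this assay compound 2 gives only a limit of the assay, > 32500 nM. Its nearest relative is compound 1 `COc1cc(-c2nn(-c3cccc(NC(=O)Nc4ccc(Cl)c(Cl)c4)c3)cc2-c2ccncc2)ccc1Cl`, which carries a methyl on the ring oxygen where compound 2 carries a hydrogen. In this assay compound 1 also gives only a limit, > 50000 nM. The step that the two limits leave unreadable from compound 1 to compound 2 therefore cannot be sized, since both values rest at limits, the limit of > 32500 nM in this assay, at which 1 of the 2 values shown sits, and (the limit of > 50000 nM in this assay, at which 1 of the 2 values shown sits).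

Compound 3 `O=C(Nc1cccc(-n2cc(-c3ccncc3)c(-c3ccc(Cl)c(O)c3)n2)c1)Nc1ccc(Cl)c(C(F)(F)F)c1` differs from compound 2 by trifluoromethyl in place of chloro on an aromatic carbon. Among the compounds with values here, no measured step speaks to this change, and the only step on record is itself unreadable. With both measured compounds at limits of this assay, compound 3 is expected to give a limit as well, and the estimated step that the limit leaves unreadable from compound 2 to compound 3 is expected to stay within the scatter. The estimate for compound 3 in this assay is 40000 nM, within 10000 nM to 100000 nM.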

Compound 3, concentration lethal to 50% of the cells: > 32500 nM
Compound 3: a limit, no number (the forecaster's own chance of this, stated with the estimate: 75%); the middle value is on the limit's open side.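

In this assay compound 3 gives > 32500 nM, which is a limit of the assay and not a number. Within the data shown here, compound 2 gives the same limit, so no step between compound 2 and compound 3 can be read. Going by these compounds, what remains open is whether trifluoromethyl in place of chloro changes the concentration lethal to cells at all.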